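Hydroxyalkyl in place of lactam on the fused ring

This account rests on a few compounds, and the source may have more. Where it says the series, first, only, none or still open, it means among the compounds named here.

Working notes on a small sulfonamide series tested in an assay on VSM-A10 cells for antagonist activity at Endothelin-1 receptor (Rattus norvegicus); on this read-out higher numbers stand for weaker inhibition and lower numbers for stronger inhibition. Three compounds have numbers. Compound 1 `Cc1noc(NS(=O)(=O)c2cccc3c(N4CCCCC4=O)cccc23)c1C` gives 270 nM in this assay. Compound 3 `CCc1noc(NS(=O)(=O)c2cccc3c(N(C)C)cccc23)c1C` gives 1170 nM in this assay, and compound 2 `Cc1noc(NS(=O)(=O)c2cccc([N+](=O)[O-])c2)c1C` gives 7800 nM in this assay. Compound 1 therefore holds the lowest number of the three and stands as the strongest inhibitor in this assay; the gaps to compound 3 and to compound 2 both lie beyond the scatter of repeated measurements. Within the data shown here, compound 3 and compound 2 also differ from compound 1 in more than one place, so no single step between measured compounds is available.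

The next compound, compound 4 `Cc1noc(NS(=O)(=O)c2cccc3c(C(C)(C)O)cccc23)c1C`, changes compound 1 in one place: 1-hydroxy-1-methylethyl in place of 2-oxopiperidin-1-yl on an aromatic carbon. The 2-oxopiperidin-1-yl group, with its six-membered non-aromatic ring, gives way to the smaller 1-hydroxy-1-methylethyl group, which brings one hydrogen-bond donor along with its acceptor.

Among the measured compounds shown here, with no measured step of this kind to go on, a modest move toward a higher number is expected in this assay, of a size near the edge of the scatter. Compound 4 is estimated at 600 nM, with a range from 150 nM to 2400 nM, which is a step of a 2.2-fold higher number from compound 1 to compound 4 (0.35 log units; beyond the scatter).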

Compound 4, half-maximal inhibitory concentration: 2890 nM
Estimate against measurement, compound 4: 4.8-fold (0.68 log units) below; the whole stated range lies below it.
By their numbers in this assay, from the lowest: compound 1; then compound 3; then compound 4; then compound 2.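

In this assay the series now has its first single-place step: 1-hydroxy-1-methylethyl in place of 2-oxopiperidin-1-yl gives an 11-fold higher number from compound 1 to compound 4 (1.03 log units; beyond the scatter) with the rest of the core of compound 1 unchanged. Among these compounds, this aromatic carbon, ortho to a fused ring and meta to a fused ring, is therefore a place where the substituent strongly affects the read-out, something the earlier compounds could not show because they differ from compound 1 in more than one place. Nothing available here accounts for the size of this step.

The step replaces a six-membered non-aromatic ring with an open group, removes the nitrogen and the double bond outside aromatic rings, lowers the heavy-atom count and adds a hydrogen-bond donor, so the compounds shown cannot separate these changes from one another. Piperidin-1-yl, which would keep the ring without the carbonyl, an open-chain N-methylacetamido group, which would keep the carbonyl without the ring, and methoxy-capped 1-methoxy-1-methylethyl, which would remove the hydroxyl hydrogen, would each isolate one part of the change on the same core.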